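This account rests on a few compounds, and the source may have more. Where it says the series, first, only, none or still open, it means among the compounds named here.

Measured so far:
Compound 1 `N#C/C=C/c1ccc(C(NC2CC2)c2ccnc(Nc3ccc(C#N)cc3)n2)cc1`; in an ADME assay on MT4 cells (Homo sapiens) for cytotoxicity, read by MTT assay, with a stated time of 5 days (a lower number here means that less compound is tolerated, a higher number that more compound is tolerated), compound 1 gives 56100 nM.
Compound 2 `N#C/C=C/c1ccc(C(NN)c2ccnc(Nc3ccc(C#N)cc3)n2)cc1`; in this assay compound 2 gives 186000 nM.

Compound 2 holds the higher of the two numbers in this assay. Among the measured compounds shown here, the single step that reaches it, a 3.3-fold higher number from compound 1 to compound 2 (0.52 log units; beyond the scatter), comes from putting amino in place of cyclopropyl on an amine nitrogen. Compound 3 `N#C/C=C/c1ccc(C(NO)c2ccnc(Nc3ccc(C#N)cc3)n2)cc1` differs from compound 2 by hydroxy in place of amino on an amine nitrogen. For the measured compounds named here, no measured step exchanges one single-heavy-atom group for another at that nitrogen; the only step available, a 3.3-fold higher number from compound 1 to compound 2 (0.52 log units; beyond the scatter), swaps a ring for amino and bears on the present change only loosely. Going by the values given here, because compound 2 gives 186000 nM and the one measured step concerns a different exchange, the expected step of a 1.0-fold lower number from compound 2 to compound 3 (0.01 log units; within the scatter) in this assay is none beyond the scatter. Compound 3 is therefore estimated at 180000 nM in this assay, with a range from 80000 nM to 400000 nM.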

Compound 3, half-maximal cytotoxic concentration: 161000 nM
The estimate for compound 3 lay 1.1-fold (0.05 log units) above the measured number, and the stated range covers the measured number.
By their numbers in this assay, from the lowest: compound 1; then compounds 3 and 2 (each within the scatter of the next).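

In this assay, hydroxy in place of amino on the amine nitrogen gives a 1.2-fold lower number from compound 2 to compound 3 (0.06 log units; within the scatter) and so leaves the number unchanged within the scatter, which means these two groups cannot be told apart at this position. Hydroxy also gives a 2.9-fold higher number from compound 1 to compound 3 (0.46 log units; beyond the scatter), a step of the same modest kind as a 3.3-fold higher number from compound 1 to compound 2 (0.52 log units; beyond the scatter), so both of these single-heavy-atom groups stand apart from cyclopropyl, and compound 1 keeps the lowest number of the three. Nothing at hand accounts for this result.

The three compounds cannot show whether the higher numbers follow from the loss of the ring or from the nature of amino and hydroxy themselves. A methyl group or a longer chain on this nitrogen would bear on that question, and a methoxy group would show whether a larger oxygen-bearing group stays level with hydroxy.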